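Working notes: from compound 2 to compound 3

A few compounds are considered here, and "the series" means these few. Any claim that something is new, unique, unknown or untested is made for them only; others in the source may bear on it.

Values measured in an ADME assay on microsomes from liver (Mus musculus) for metabolic stability, read by LC-MS, with a stated time of 30 min, tested at 1 uM (a lower number here means that less of the compound is left, a higher number that more of the compound is left), so far:
compound 1 `O=C(NCc1ccc(S(=O)(=O)c2ccccc2)cc1)c1nc2cnccc2[nH]1` gives 7.3%
compound 2 `O=C(NCc1ccc(S(=O)(=O)N2CCCCC2)cc1)c1cc2cnccc2s1` gives "below limit of detection" (no number reported)

Compound 2 has no single number to stand on here. For compound 2 the entry "below limit of detection" (no number reported) is a report in words and not a number. Still unmeasured is compound 3 `O=C(NCc1ccc(S(=O)(=O)N2CCCCC2)cc1)c1ccc2nc[nH]c2c1` in this series. The structural change is a group of 9 heavy atoms (7 carbon, 2 nitrogen; one five-membered aromatic ring with 2 hetero atoms, one six-membered aromatic ring of carbon only) in place of a group of 9 heavy atoms (7 carbon, 1 nitrogen, 1 sulfur; one five-membered aromatic ring with 1 hetero atom, one six-membered aromatic ring with 1 hetero atom), on a carbonyl carbon with 1H-benzimidazol-6-yl entering on a carbonyl carbon. Among the measured compounds shown here, no measured step in this assay speaks directly to this change, so only a small upward step is expected, not far beyond the scatter. For the measured compounds named here, compound 1 gives 7.3% as the only number in hand, and the expectation stays low on that basis. The estimate for compound 3 is 6% as the expected value, with an expected range from 1% to 20% for the percent remaining.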

Compound 3, percent of the compound remaining: 16%
Estimate against measurement, compound 3: 10 percentage points below, and the stated range covers the measured number.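

No step can be read from compound 2 to compound 3: in this assay compound 2 has a report in words, not a number. The compounds shown leave open what the 1H-benzimidazol-6-yl group alone changes in the percent remaining. Nothing in hand bears on a cause for this result.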